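This account rests on a few compounds, and the source may have more. Where it says the series, first, only, none or still open, it means among the compounds named here.

Compound 1 `Cc1cccc(N2CCn3c2n[nH]c(=O)c3=O)c1C`: 22%
Compound 2 `N=c1c(=O)[nH]nc2n1CCN2c1ccc(Cl)cc1`: 27%

In a functional assay on T47D cells (Homo sapiens) for cytotoxicity, with a stated time of 72 h, tested at 50 ug/mL (a lower number here means a weaker effect, a higher number a stronger effect of the compound at the concentration tested), compound 2 gives 27%, the higher of the two numbers, while compound 1 gives 22%, a value lying within the usual scatter of that result. Compound 3 `Cc1ccc(N2CCn3c2n[nH]c(=O)c3=N)cc1` has not yet been measured. It differs from compound 2 by methyl in place of chloro on an aromatic carbon. Among the compounds with values here, with no step between measured compounds to draw on, only a small change in this assay is expected, most likely within the scatter and if anything slightly downward. Compound 3 is therefore estimated at 24%, with a range from 12% to 38%. The expected step from compound 2 to compound 3 is a number 3 percentage points lower from compound 2 to compound 3 (within the scatter).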

Compound 3, a percentage reported as inhibition, at one concentration (the size of the read-out at that concentration, not a potency): 0%
The estimate for compound 3 lay 24 percentage points above the measured number, outside the stated range (below it).
By their numbers in this assay, from the lowest: compound 3; then compounds 1 and 2 (each within the scatter of the next).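

In this assay, within the data shown here, methyl in place of chloro on an aromatic carbon, para to a large group, gives a number 27 percentage points lower from compound 2 to compound 3 (beyond the scatter) and provides the first comparison that differs in one place. It shows that the read-out is sensitive to the group at this position, at least for this pair. No available evidence explains the step. A single pair cannot show whether the loss is specific to methyl or follows from removing chloro. A fluoro group, a methoxy group or an amine at this position would help separate those possibilities.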